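The source may hold more compounds than are shown below. What is called first, only, known or untested is meant among the compounds shown, and "the series" means these compounds.

Of the compounds shown here, three share one core and have been tested in a functional assay on Hep 3B2 cells (Homo sapiens) for antiproliferative activity, read by MTT assay, with a stated time of 24 h, tested at 33.33 ug/mL; on this read-out lower numbers stand for a weaker effect and higher numbers for a stronger effect at the one concentration tested. Compound 1 `Cc1c(C(=O)Nc2c(F)cc(-c3cccc(F)c3)cc2F)nc2ccc(C(F)(F)F)cc2c1O` gives 45.2% in this assay. Compound 2 `COc1ccc2nc(C(=O)Nc3ccc(-c4ccccc4)cc3)c(C)c(O)c2c1` gives 48.4%. Compound 3 `Cc1c(C(=O)Nc2ccc(-c3ccccc3)cc2)nc2ccccc2c1O` gives 46.2%. These three numbers lie close together: compound 3 stands second highest of the three, with compound 1 nearest and compound 2 furthest, and both gaps fall within the scatter. Going by the values given here, the only single-point change measured so far is a number 2.2 percentage points lower from compound 2 to compound 3 (within the scatter), a hydrogen in place of methoxy on an aromatic carbon, and it left the read-out essentially unchanged.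

Compound 4 `Cc1c(C(=O)Nc2ccc(-c3ccccc3)cc2)nc2ccccc2c1C(=O)O` differs from compound 3 in one place: carboxy in place of hydroxy on an aromatic carbon. Among the compounds with values here, no measured step swaps a hydroxy for a carboxy, and this change has no direct precedent among the three compounds. Within the data shown here, the one step that is known, from a methoxy to a hydrogen, stayed within the scatter, and the three values span only a narrow band. On that basis compound 4 is expected to stay near compound 3, with the step of a number 3.2 percentage points lower from compound 3 to compound 4 (within the scatter) expected to fall within the scatter. As far as these compounds go, the change itself is untested, and the range is kept wide. The estimate for compound 4 is 43%, between 26% and 58%.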

Compound 4, a percentage reported as inhibition, at one concentration (the size of the read-out at that concentration, not a potency): 11.3%
For compound 4 the middle estimate is 31.7 percentage points above the measured one, and the stated range ends above it.
By their numbers in this assay, from the lowest: compound 4; then compounds 1, 3 and 2 (each within the scatter of the next).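

In this assay, going by these compounds alone, carboxy in place of hydroxy on this aromatic carbon, opposite the ring nitrogen, gives a number 34.9 percentage points lower from compound 3 to compound 4 (beyond the scatter) and is the first change to move the read-out clearly. Within the data shown here, the only earlier single change, methoxy to hydrogen at a different place, gave a number 2.2 percentage points lower from compound 2 to compound 3 (within the scatter) and so showed no such sensitivity, whereas this position clearly does not accept every group. Both groups count the same hydrogen-bond donors and acceptors, and nothing measured here explains the drop.

As far as these compounds go, with only hydroxy and carboxy compared at this position, it remains open whether the loss follows from carboxy specifically or from removing hydroxy. A methyl ester, a primary amide or an amine on the same carbon would help separate these two readings.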